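Dimethylamino in Place of Phenoxy: An Expected Small Step

The source may report more compounds than this note shows. Statements on the series, on what has been measured and on what is new or still open speak of the compounds shown alone.

Of the compounds shown here, two have so far been measured in a functional assay on SNB-75 cells (Homo sapiens) for cytotoxicity, read by sulforhodamine B assay, with a stated time of 48 h, tested at 0.01 uM; a lower number here means a stronger effect, a higher number a weaker effect of the compound at the concentration tested. Compound 1 `COc1cc(C)cc(-c2nn(CC#N)cc2-c2ccc(-c3cccc(C(C)=O)c3)nc2)c1` gives 83% in this assay. Compound 2 `Cc1cc(O)cc(-c2nn(CC#N)cc2-c2ccnc(-c3ccc(Oc4ccccc4)cc3)c2)c1` gives 79% in this assay; this is the lowest of the two numbers, yet compound 1 sits within the scatter of it, so the two values show no difference beyond the usual scatter of such measurements. Compound 3 `Cc1cc(O)cc(-c2nn(CC#N)cc2-c2ccnc(-c3ccc(N(C)C)cc3)c2)c1` has not yet been measured in this assay. It differs from compound 2 in one place: dimethylamino in place of phenoxy on an aromatic carbon. Among the compounds with values here, no step between measured compounds that differ in one place is known, so the size of this change cannot be read from the measured pair. Within the data shown here, with no measured step to guide it, the expected step of a number 3 percentage points higher from compound 2 to compound 3 (within the scatter) is small, in no direction beyond the scatter. Compound 3 is therefore estimated at 82%, within a range from 66% to 98%.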

Compound 3, a percentage reported as activity, at one concentration (the size of the read-out at that concentration, not a potency): 75%
For compound 3 the middle estimate is 7 percentage points above the measured one; the measured number falls inside the stated range.
By their numbers in this assay, from the lowest: compounds 3, 2 and 1 (each within the scatter of the next).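

This exchange gives the series its first step between compounds that differ in one place: with dimethylamino in place of phenoxy on an aromatic carbon, para to a large group, this assay shows a number 4 percentage points lower from compound 2 to compound 3 (within the scatter). Phenoxy, with 7 heavy atoms and a six-membered aromatic ring of carbon only, can therefore give way to dimethylamino, with 3 heavy atoms and no ring, without the read-out moving beyond the scatter at this one concentration. No measured evidence bears on why the read-out stays within the scatter.

On these data alone, it remains open whether any group at this position would move the number beyond the scatter, for example a carboxylic acid, a primary amine or a longer chain. A single concentration also leaves the potency of these compounds unknown.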